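The compounds below may be only part of what the source reports. "The series", "measured", "known", "first", "only" and "open" are said of these compounds alone.

Compound 1 `N#CC1=C(N)Oc2c(c3nc4ccccc4nc3c3ccccc23)C12C(=O)N(Cc1cnnn1-c1cccc(Cl)c1)c1ccccc12` and compound 2 `Cc1ccccc1-n1nncc1CN1C(=O)C2(C(C#N)=C(N)Oc3c(N)cc4nc5ccccc5nc4c32)c2ccccc21` share one core and were both examined in a functional assay on HepG2 cells (Homo sapiens) for antiproliferative activity, read by MTT assay, with a stated time of 48 h; a lower number here means a stronger inhibitor, a higher number a weaker inhibitor. Compound 1 gives only a limit in this assay, namely > 50000 nM. Compound 2 also gives only a limit in this assay, namely > 50000 nM. Among the compounds with values here, compound 2 thus stands at the limit of > 50000 nM in this assay, at which 2 of the 2 values shown sit, and no step between measured compounds is available. Compound 3 `CCc1ccccc1-n1nncc1CN1C(=O)C2(C(C#N)=C(N)Oc3c(N)cc4nc5ccccc5nc4c32)c2ccccc21` differs from compound 2 by methyl in place of hydrogen on a saturated chain carbon bound to an aromatic carbon. From the data shown, the expected step that the limit leaves unreadable from compound 2 to compound 3 is none beyond the scatter. Compound 3 is estimated at 60000 nM, within 20000 nM to 200000 nM, most likely reported again as a limit.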

Compound 3, half-maximal inhibitory concentration: 17900 nM
For compound 3 the middle estimate is 3.4-fold (0.53 log units) above the measured one; measured number outside the range, below it.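

Methyl in place of hydrogen on a saturated chain carbon bound to an aromatic carbon, which turns 2-methylphenyl into 2-ethylphenyl, gives an at least 2.7-fold lower number from compound 2 to compound 3 (0.44 log units; beyond the scatter). In this assay, within the data shown here, this position therefore responds to a change, which the earlier compounds, both limits, could not show. The step is only a lower bound, since it starts from a limit: the limit of > 50000 nM in this assay, at which 2 of the 3 values shown sit.

From the compounds shown here alone, what a longer chain such as propyl, or a methoxy group, would do at this position remains open. A single step also cannot show whether the number keeps falling as the chain grows.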